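Trading two chlorines for one fluorine on the aryl ether

The compounds below may be only part of what the source reports. "The series", "measured", "known", "first", "only" and "open" are said of these compounds alone.

Measured compounds in this study:
compound 1 `NC1=NC2(CCOCC2)N(OCCCOc2ccccc2)C(N)=N1`: > 90%
compound 2 `NC1=NC2(CCOCC2)N(OCCCOc2cccc(Cl)c2Cl)C(N)=N1`: 81.7%

In an assay on isolated protein for inhibition of Dihydrofolate reductase (Homo sapiens), read by spectrophotometry, using NADPH, with stated times of 5 s and 6 min, tested at 5 uM (a higher number here means a stronger effect of the compound at the concentration tested, a lower number a weaker effect), compound 1 reaches the limit of the assay, > 90%. Compound 2 gives 81.7% in this assay, and among the numbers shown it is the only plain value. The other number, that of compound 1, is a limit (the limit of > 90% in this assay, at which 1 of the 2 values shown sits). Among the compounds with values here, the one measured step, a number at least 8.3 percentage points lower from compound 1 to compound 2 (that floor lies within the scatter), cannot be sized precisely, and the smallest gap it allows lies within the usual scatter, so it offers little guidance.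

Compound 3 `NC1=NC2(CCOCC2)N(OCCCOc2ccc(F)cc2)C(N)=N1` has not been measured. It differs from compound 2 in a single place: 4-fluorophenyl in place of 2,3-dichlorophenyl on an oxygen on a saturated carbon. Nothing measured here speaks directly to a fluorine on this ring. Since removing the two chlorines would move the structure back toward compound 1, and compound 1 sits at the limit, the step of a number 6.3 percentage points higher from compound 2 to compound 3 (within the scatter) is expected to be small and upward, and not clearly beyond the scatter. Compound 3 is therefore estimated at 88%, within a range from 76% to 96%.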

Compound 3, a percentage reported as inhibition, at one concentration (the size of the read-out at that concentration, not a potency): > 90%
Compound 3 ended at the assay's limit; the forecaster's own chance of this, stated with the estimate: 35%; middle value at least 2 percentage points away from the limit.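

At this position, 4-fluorophenyl in place of 2,3-dichlorophenyl gives a number at least 8.3 percentage points higher from compound 2 to compound 3 (that floor lies within the scatter) in this assay. The floor of that step does not clear the scatter, so it does not establish that the fluorine is better than the two chlorines, but it does show something compound 1 and compound 2 could not: a phenyl ring carrying a substituent can still reach the top of the readable range. The step from compound 1 to compound 3, fluoro in place of hydrogen on an aromatic carbon, cannot be read, and nothing can be said about whether the fluorine helps or harms relative to the bare ring, since both compounds rest at the same ceiling: the limit of > 90% in this assay, at which 2 of the 3 values shown sit.

The change from compound 2 to compound 3 alters the kind, the number and the placing of the halogens all at once, so a ring carrying a single chlorine would be needed to begin separating these, and a ring bearing an amine or a carboxylic acid would test how far this tolerance extends. From the compounds shown here alone, how compound 1 and compound 3 truly compare also stays open until both give plain numbers instead of limits.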